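Oxan-4-yl for pyrimidin-2-yl on the carbonyl carbon

The source may report more compounds than this note shows. Statements on the series, on what has been measured and on what is new or still open speak of the compounds shown alone.

Measured so far in a functional assay on COR-L23 cells (Homo sapiens) for antiproliferative activity, read by CellTiter-Glo, with a stated time of 72 h; a higher number here means a weaker inhibitor, a lower number a stronger inhibitor

compound 1 `C[C@@H](c1ccc(NC(=O)N2CC(c3cccnc3)C2)cc1)N1Cc2ccccc2C1=O` gives 8 nM
compound 2 `C[C@H](NC(=O)c1ncccn1)c1ccc(NC(=O)N2CC(c3cccnc3)C2)cc1` gives 130 nM

Within the data shown here, compound 2 holds the higher of the two numbers, and the only measured step is a 16-fold higher number from compound 1 to compound 2 (1.21 log units; beyond the scatter). Compound 3 `C[C@H](NC(=O)C1CCOCC1)c1ccc(NC(=O)N2CC(c3cccnc3)C2)cc1` is next, and it differs from compound 2 in one place (oxan-4-yl in place of pyrimidin-2-yl on a carbonyl carbon). An aromatic ring with two hetero atoms thus gives way to a non-aromatic ring with one, while the amide-type nitrogen stays.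

The measured step bears on this only indirectly. Among the measured compounds shown here, it exchanged the whole group on the saturated chain carbon, including the carbonyl, and no measured pair isolates a change on the carbonyl carbon itself. It does show that compound 2 can be moved far by a change in this part of the molecule, as a 16-fold higher number from compound 1 to compound 2 (1.21 log units; beyond the scatter) makes clear, so the range has to stay wide on both sides.

For the measured compounds named here, with no direct precedent, no shift beyond the scatter is expected in this assay, and the estimated step is a 1.4-fold lower number from compound 2 to compound 3 (0.16 log units; within the scatter) as a slight lean only. For compound 3 the expected value is 90 nM with an estimated range from 25 nM to 350 nM in this measurement.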

Compound 3, half-maximal inhibitory concentration: 58 nM
Beside the measured number, compound 3's estimate is 1.6-fold (0.19 log units) above it, within the range that was stated.
By their numbers in this assay, from the lowest: compound 1; then compound 3; then compound 2.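

In this assay, among these compounds, oxan-4-yl in place of pyrimidin-2-yl gives the first measured change on the carbonyl carbon itself, with a 2.2-fold lower number from compound 2 to compound 3 (0.35 log units; beyond the scatter) as the result, so a six-membered aromatic ring with 2 hetero atoms is not required at this place and a six-membered non-aromatic ring with 1 hetero atom is accepted. The exchange of the whole group on the saturated chain carbon still costs a 7.3-fold higher number from compound 1 to compound 3 (0.86 log units; beyond the scatter) when the new group carries oxan-4-yl, a smaller step than a 16-fold higher number from compound 1 to compound 2 (1.21 log units; beyond the scatter) but one that leaves compound 3 short of compound 1 in this assay. Nothing available gives a measured reason for the shift produced by this change on the carbonyl carbon.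

The compounds shown leave open whether the ring oxygen of oxan-4-yl matters, which cyclohexyl on the same carbonyl carbon would test, and whether a ring is needed there at all, which a short chain such as ethyl would test. Also open, as far as these compounds go, is whether an amine such as piperidin-4-yl at this place would keep the number of compound 3 or bring it closer to that of compound 1, which gives 8 nM.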